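The source may hold more compounds than are shown below. What is called first, only, known or untested is meant among the compounds shown, and "the series" means these compounds.

Measured compounds:
compound 1, `ClCc1ccccc1Cn1cnc2c(Cl)nc(Cl)nc21`: 6760 nM
compound 2, `ClCc1ccccc1Cn1cnc2c(Cl)ncnc21`: > 100000 nM
compound 3, `ClCc1ccc(Cn2cnc3nc(Cl)nc(Cl)c32)cc1`: 38000 nM

In a functional assay on NCI-H522 cells (Homo sapiens) for cytotoxicity, read by sulforhodamine B assay, with a stated time of 48 h (a higher number here means that more compound is tolerated, a lower number that less compound is tolerated), compound 1 gives 6760 nM. For compound 2 the value in this assay is a limit of the assay, > 100000 nM, as noted in the limit of > 100000 nM in this assay, at which 1 of the 3 values shown sits. The change from compound 1 to compound 2 is hydrogen in place of chloro on an aromatic carbon, and it gave an at least 14-fold higher number from compound 1 to compound 2 (1.17 log units; beyond the scatter). Compound 3 gives 38000 nM in this assay; how its core differs from that of compound 1 is not broken down here.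

Compound 4, `ClCc1ccc(Cn2cnc3ncnc(Cl)c32)cc1`, is not yet measured. It differs from compound 3 by hydrogen in place of chloro on an aromatic carbon, the same change as that from compound 1 to compound 2, at a place described in the same words. On that single precedent, the step from compound 3 to compound 4 in this assay is expected to be large in the same direction, about a 4.7-fold higher number from compound 3 to compound 4 (0.68 log units; beyond the scatter), resting on an at least 14-fold higher number from compound 1 to compound 2 (1.17 log units; beyond the scatter). Compound 3 already sits at 38000 nM. The estimate for compound 4 is 180000 nM, within 60000 nM to 600000 nM.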

Compound 4, concentration lethal to 50% of the cells: > 100000 nM
Compound 4: a limit, no number; the forecaster's own chance of this, stated with the estimate: 70%; the middle value lies beyond the limit too.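

In this assay compound 4 gives > 100000 nM as a limit of the assay. Hydrogen in place of chloro on an aromatic carbon again goes with a higher number, with an at least 2.6-fold higher number from compound 3 to compound 4 (0.42 log units; beyond the scatter) on the core of compound 3, so the direction of the change holds on both cores shown. This does not show that the size of the change carries from one core to the other, and two cores are too few to support a rule for the series: the same change on two cores in this assay, an at least 14-fold higher number (1.17 log units; beyond the scatter) from compound 1 to compound 2 and an at least 2.6-fold higher number (0.42 log units; beyond the scatter) from compound 3 to compound 4; the limit leaves it open whether they differ

The compounds shown leave open what a group other than hydrogen, such as an amine or a methoxy group, would do at the place between two ring nitrogen atoms on either core. Equally open, as far as these compounds go, is what the same groups would do in place of the chloro group retained in compound 2 and compound 4, where any further rise in the number could not be read beyond the limit of the assay.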